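Compound 4 and a flat series of amides

This account rests on a few compounds, and the source may have more. Where it says the series, first, only, none or still open, it means among the compounds named here.

Compound 1 `COc1ccc(NC(=O)c2cccc(Nc3ncc(F)c(Nc4ccc(F)cc4)n3)c2)cc1` gives 15700 nM
Compound 2 `O=C(c1cccc(Nc2ncc(F)c(Nc3ccc(F)cc3)n2)c1)N1CCCCC1` gives 13800 nM
Compound 3 `O=C(Nc1cccc(Nc2ncc(F)c(Nc3ccc(F)cc3)n2)c1)c1cccc([N+](=O)[O-])c1` gives 11400 nM

In a functional assay on KBVIN cells (Homo sapiens) for antiproliferative activity, read by sulforhodamine B assay, with a stated time of 3 days (on this read-out lower numbers stand for stronger inhibition of growth and higher numbers for weaker inhibition of growth), compound 3 gives 11400 nM, a number within the scatter of those for compound 1 and compound 2, so the three cannot be ranked. The step of interest leads to compound 4 `O=C(Nc1cccc(Nc2ncc(F)c(Nc3ccc(F)cc3)n2)c1)c1ccncc1`, with pyridin-4-yl in place of 3-nitrophenyl on a carbonyl carbon. Among the measured compounds shown here, only one measured step bears on this change, and only loosely. It is a 1.1-fold lower number from compound 1 to compound 2 (0.06 log units; within the scatter), also an exchange on a carbonyl carbon, though of different groups. For the measured compounds named here, that step stays within the scatter, and no measured compound carries pyridin-4-yl. On this limited evidence, no shift beyond the scatter is expected in this assay, and no direction can be favoured. The estimate amounts to an expected 1.1-fold higher number from compound 3 to compound 4 (0.04 log units; within the scatter). Compound 4 is estimated at 12500 nM, with an expected range of 5500 nM to 28000 nM.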

Compound 4, concentration for 50% growth inhibition: 4570 nM
Beside the measured number, compound 4's estimate is 2.7-fold (0.44 log units) above it; the whole stated range lies above it.
By their numbers in this assay, from the lowest: compound 4; then compounds 3, 2 and 1 (each within the scatter of the next).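

In this assay, among the compounds shown here, putting pyridin-4-yl in place of 3-nitrophenyl on a carbonyl carbon gives a 2.5-fold lower number from compound 3 to compound 4 (0.40 log units; beyond the scatter), the first step in this set to pass beyond the scatter, although the size is modest. For the compounds shown here, the other two amides also differ from the new compound by more than the scatter, with a 3.0-fold lower number from compound 2 to compound 4 (0.48 log units; beyond the scatter) and a 3.4-fold lower number from compound 1 to compound 4 (0.54 log units; beyond the scatter), so the group at this place can shift growth inhibition, which the earlier compounds, all within the scatter of their neighbours, did not show. Nothing available explains this shift.

The compounds shown leave open whether the lower number belongs to pyridin-4-yl alone or would also appear with pyridin-3-yl or an unsubstituted phenyl on this carbonyl carbon. They also leave open whether a carboxylic acid or a longer chain in place of the ring would keep it.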